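Swapping the phenyl group: from compound 3 to compound 4

The source may hold more compounds than are shown below. What is called first, only, known or untested is meant among the compounds shown, and "the series" means these compounds.

Compound 1 `CC1(C)[C@H]2CC[C@]1(C)N(Cc1cn(-c3cccc(C#N)c3)nn1)C(=O)C2`: 40 nM
Compound 2 `CC1(C)[C@H]2CC[C@]1(C)N(Cc1cn(-c3ccccc3Cl)nn1)C(=O)C2`: 60 nM
Compound 3 `COc1ccccc1-n1cc(CN2C(=O)C[C@@H]3CC[C@@]2(C)C3(C)C)nn1`: 110 nM

All three values come from a functional assay on HepG2 cells (Homo sapiens) for inhibition, read by MTT assay, with a stated time of 24 h; on this read-out higher numbers stand for weaker inhibition and lower numbers for stronger inhibition. The compounds share one core and differ only in the substituted phenyl group on an aromatic nitrogen. Where compound 3 stands is told by two steps: a 1.8-fold higher number from compound 2 to compound 3 (0.26 log units; within the scatter), and a 2.8-fold higher number from compound 1 to compound 3 (0.44 log units; beyond the scatter).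

The next compound is compound 4 `CC1(C)[C@H]2CC[C@]1(C)N(Cc1cn(-c3ccc(O)cc3)nn1)C(=O)C2`, which has not yet been measured in this assay. The change is 4-hydroxyphenyl in place of 2-methoxyphenyl on an aromatic nitrogen.

Among the compounds with values here, the steps that bear on this change are the swaps at that same nitrogen. Besides the two above, the data show a 1.5-fold higher number from compound 1 to compound 2 (0.18 log units; within the scatter). Within the data shown here, of these three steps, only the one from compound 1 to compound 3 passes the scatter, and it is modest. Among the measured compounds shown here, none of the measured compounds carries a hydroxy group, so the new group itself is untested, and this widens the range of the expectation.

On these steps, no change beyond the scatter is expected, and the expected step is a 1.2-fold lower number from compound 3 to compound 4 (0.09 log units; within the scatter). The estimated value for compound 4 is 90 nM, with an expected range from 30 nM to 300 nM.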

Compound 4, half-maximal inhibitory concentration: 80 nM
Compound 4: the middle estimate sits 1.1-fold (0.05 log units) above what was measured; measured number inside the range.
By their numbers in this assay, from the lowest: compounds 1, 2, 4 and 3 (each within the scatter of the next, the first and the last beyond it).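

In this assay, within the data shown here, the first phenyl group on this aromatic nitrogen to count a hydrogen-bond donor, 4-hydroxyphenyl, stays within the scatter of the two closest groups, with a 1.4-fold lower number from compound 3 to compound 4 (0.14 log units; within the scatter) and a 1.3-fold higher number from compound 2 to compound 4 (0.12 log units; within the scatter). Among these compounds, the comparison with the 3-cyanophenyl group, a 2.0-fold higher number from compound 1 to compound 4 (0.30 log units; within the scatter), is also printed as within the scatter, so compound 4 cannot be separated from any of the three earlier compounds, and a 2.8-fold higher number from compound 1 to compound 3 (0.44 log units; beyond the scatter) remains the only step beyond it. No measurement shown here gives a reason for this result.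

The swap from 2-methoxyphenyl to 4-hydroxyphenyl changes both the group and its place on the phenyl ring, so the compounds shown cannot tell these two changes apart. From the compounds shown here alone, it also remains open whether a carboxylic acid or an amine on the phenyl ring would give a number that stands clear of this narrow set.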